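The source may hold more compounds than are shown below. What is called first, only, known or untested is meant among the compounds shown, and "the series" means these compounds.

In an ADME assay on MT2 cells (Homo sapiens) for cytotoxicity, read by MTT assay, with a stated time of 3 days (on this read-out lower numbers stand for stronger inhibition and higher numbers for weaker inhibition), compound 1 (`CN(C)c1ccnc(CNCCSC(c2ccccc2)(c2ccccc2)c2ccccc2)c1`) gives 3160 nM, compound 2 (`CCN(CC)c1ccnc(CNCCSC(c2ccccc2)(c2ccccc2)c2ccccc2)c1`) gives 2220 nM, and compound 3 (`c1ccc(C(SCCNCc2ccccn2)(c2ccccc2)c2ccccc2)cc1`) gives 3560 nM. Compound 1 therefore stands in a close group of three numbers, with no separation from either of the others: the data show a 1.4-fold lower number from compound 1 to compound 2 (0.15 log units; within the scatter) and a 1.1-fold higher number from compound 1 to compound 3 (0.05 log units; within the scatter), while the remaining pair shows a 1.6-fold higher number from compound 2 to compound 3 (0.21 log units; within the scatter).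

Compound 4 (`COC(=O)[C@@H](CSC(c1ccccc1)(c1ccccc1)c1ccccc1)NCc1cc(N(C)C)ccn1`) keeps the dimethylamino group of compound 1 and differs at the chain: methoxycarbonyl in place of hydrogen on a saturated chain carbon bound to an amine nitrogen and a saturated chain carbon. Among the measured compounds shown here, no measured step touches that place. All three concern the group on an aromatic carbon, so they bear on this change only indirectly, as a sign of how little the read-out moved across the series. For the measured compounds named here, no measured compound carries methoxycarbonyl, and the data give no size for its introduction. With a 1.1-fold higher number from compound 1 to compound 3 (0.05 log units; within the scatter) as the closest guide, no step beyond the scatter is expected in this assay, and no direction can be argued from the data. The estimated change is a 1.1-fold lower number from compound 1 to compound 4 (0.02 log units; within the scatter). For compound 4 the estimated value is 3000 nM, with an expected range from 1200 nM to 7500 nM.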

Compound 4, half-maximal inhibitory concentration: 3150 nM
The estimate for compound 4 lay 1.1-fold (0.02 log units) below the measured number; measured number inside the range.
By their numbers in this assay, from the lowest: compounds 2, 4, 1 and 3 (each within the scatter of the next).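

Until this point every step in this assay concerned the group on an aromatic carbon. Among the compounds shown here, the step of a 1.0-fold lower number from compound 1 to compound 4 (0.00 log units; within the scatter) gives the first reading at a different place, the saturated chain carbon bound to an amine nitrogen and a saturated chain carbon, and it shows that methoxycarbonyl, with its 4 heavy atoms and no net charge, can stand there in place of hydrogen without separating the two numbers. The read-out is thus as flat at this chain position, for this one group, as it was for the three groups compared on the aromatic carbon, and nothing reported alongside these numbers offers an explanation for this reading.

What the compounds shown leave open is whether this flat reading belongs to the position or only to methoxycarbonyl, since a carboxylic acid, a primary amide or a longer ester at the same carbon could read differently. As far as these compounds go, it also remains open whether methoxycarbonyl would read the same with diethylamino or hydrogen in place of dimethylamino on the aromatic carbon.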